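Oxolanyl acyl variant of compound 1: solubility outlook

The source may hold more compounds than are shown below. What is called first, only, known or untested is meant among the compounds shown, and "the series" means these compounds.

Among the measured compounds shown here, compound 1 `CC(C)C(=O)N1CCC(NC(=O)Nc2ccc(C(F)(F)F)c(F)c2)CC1` gives 5.9 ug/mL in a physicochemical assay for solubility, read by mass spectrometry, in phosphate buffer, with a stated time of 24 h, at pH 7.4; a higher number here means a more soluble compound, a lower number a less soluble compound; it stands second highest of the three numbers so far. Compound 2 `CC(C)C(=O)N1CCC(NC(=O)Nc2ccc(OC(F)(F)F)c(F)c2)CC1` gives 5.3 ug/mL, and the step of a 1.1-fold lower number from compound 1 to compound 2 (0.05 log units; within the scatter) lies within the scatter. Compound 3 `CC[C@H](C)C(=O)N1CCC(CC(=O)Nc2ccc(OC(F)(F)F)c(F)c2)CC1` gives 21 ug/mL, the highest value, but it differs from compound 1 in more than one place, so only the two values themselves can be compared. Compound 4 `O=C(Nc1ccc(C(F)(F)F)c(F)c1)NC1CCN(C(=O)[C@@H]2CCOC2)CC1` differs from compound 1 by oxolan-3-yl in place of isopropyl on a carbonyl carbon. For the measured compounds named here, no measured step touches the acyl group, so nothing here calibrates this change; the step of a 1.7-fold higher number from compound 1 to compound 4 (0.23 log units; within the scatter) is therefore expected to be small, most likely within the scatter or a modest rise. For compound 4 an estimate of 10 ug/mL is given, between 4 ug/mL and 25 ug/mL.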

Compound 4, solubility: 1.9 ug/mL
Beside the measured number, compound 4's estimate is 5.3-fold (0.72 log units) above it; measured number below the stated range.
By their numbers in this assay, from the lowest: compound 4; then compounds 2 and 1 (each within the scatter of the next); then compound 3.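

Among the compounds shown here, the earlier compounds left the acyl group untouched, and this is the first reading at the carbonyl carbon: in this assay oxolan-3-yl in place of isopropyl gives a 3.1-fold lower number from compound 1 to compound 4 (0.49 log units; beyond the scatter). The number at this position therefore moves beyond the scatter with the acyl group alone, while the rest of compound 1 stays the same. No measurement here bears on why this step goes the way it does.

Still open, going by these compounds, is whether the ring carbons or the ring oxygen of oxolan-3-yl go with this step, which cyclopentyl or a methoxyethyl chain on the same carbonyl carbon would separate. On these data alone, an amine on that acyl group and the opposite stereocentre of oxolan-3-yl also remain open.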